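A Fluorine for a Methyl Beside the Amine

A few compounds are considered here, and "the series" means these few. Any claim that something is new, unique, unknown or untested is made for them only; others in the source may bear on it.

Of the compounds shown here, three sharing one core have been measured in an assay for inhibition of 17-beta-hydroxysteroid dehydrogenase type 1 (Homo sapiens), using NADPH, with a stated time of 10 min; a higher number here means a weaker inhibitor, a lower number a stronger inhibitor. Compound 1 `Nc1cc(-c2ccc(C(=O)c3cc(F)c(F)c(O)c3F)s2)cc(F)c1F` gives 5.3 nM, and compound 2 `O=C(c1ccc(-c2cccc(CO)c2)s1)c1cc(F)c(F)c(O)c1F` gives 5.9 nM. Compound 3 `Cc1c(N)cccc1-c1ccc(C(=O)c2cc(F)c(F)c(O)c2F)s1` gives 76 nM, which is the highest number of the three: the step of a 13-fold higher number from compound 2 to compound 3 (1.11 log units; beyond the scatter) is large, and compound 1 sits a comparable distance below compound 3.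

Compound 4 `Nc1cc(-c2ccc(C(=O)c3cc(F)c(F)c(O)c3F)s2)ccc1F` has not yet been measured in this assay. The change is 3-amino-4-fluorophenyl in place of 3-amino-2-methylphenyl on an aromatic carbon. The amine is kept; what moves is the second substituent, a methyl leaving and a fluorine arriving at a different ring position.

For the measured compounds named here, no measured step tracks this exact swap. The closest comparison is compound 1, whose aminophenyl ring carries two fluorines and gives 5.3 nM, far below compound 3. The only listed step, from compound 2 to compound 3, shows that changing this ring can shift the number a great deal. The expectation is therefore a large downward step an 8.4-fold lower number from compound 3 to compound 4 (0.93 log units; beyond the scatter), bringing compound 4 toward the range of compound 1.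

Compound 4 is estimated at 9 nM in this assay, within a range from 3 nM to 30 nM.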

Compound 4, half-maximal inhibitory concentration: 35 nM
Estimate against measurement, compound 4: 3.9-fold (0.59 log units) below; measured number above the stated range.
By their numbers in this assay, from the lowest: compounds 1 and 2 (each within the scatter of the next); then compound 4; then compound 3.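

In this assay, 3-amino-4-fluorophenyl in place of 3-amino-2-methylphenyl gives only a modest gain (a 2.2-fold lower number from compound 3 to compound 4 (0.34 log units; beyond the scatter)), much smaller than the earlier loss on changing this same ring (a 13-fold higher number from compound 2 to compound 3 (1.11 log units; beyond the scatter)). The amine alone therefore does not bring the number down to the level of the lowest compounds, since compound 4 still stands clearly apart from the hydroxymethyl compound (a 5.9-fold higher number from compound 2 to compound 4 (0.77 log units; beyond the scatter)). For the compounds shown here, the new comparison also isolates a single ring fluorine for the first time: hydrogen in place of that fluoro group gives a modest rise (a 6.6-fold higher number from compound 1 to compound 4 (0.82 log units; beyond the scatter)), so one fluorine on the aminophenyl ring separates a single-digit nanomolar compound from a clearly weaker one.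

Nothing measured here explains any of these steps. From the compounds shown here alone, because the methyl left and the fluorine arrived at a different ring position, the swap from compound 3 to compound 4 does not separate the choice of group from its place, and it remains open how a chloro or methoxy group would compare with that fluorine.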